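Methoxy Added Ortho to Methoxy: Compound 4 Expected

A few compounds are considered here, and "the series" means these few. Any claim that something is new, unique, unknown or untested is made for them only; others in the source may bear on it.

Measured compounds:
compound 1, `O=C1OC(c2ccc(Cl)c([N+](=O)[O-])c2)=N/C1=C\c1ccncc1`, 10%
compound 2, `COc1cccc(C2=N/C(=C\c3cccnc3)C(=O)O2)c1`, 100%
compound 3, `COc1ccc(C2=N/C(=C\c3cccnc3)C(=O)O2)c(Br)c1`, 92%

Three compounds sharing one core were examined in an assay on isolated protein for inhibition of Death-associated protein kinase 3 (Homo sapiens), tested at 10 uM; on this read-out higher numbers stand for a stronger effect at the one concentration tested and lower numbers for a weaker effect. Compound 2 gives 100%, the highest of the three numbers. Compound 3 gives 92%, a number within the usual scatter of that of compound 2, so the two cannot be told apart. Among the compounds with values here, compound 1 gives 10%, far below the other two and beyond the scatter; its aryl ring carries a chloro group and a nitro group where compound 2 carries a methoxy group, but no single-change step connects it to compound 2, so only the two values themselves can be compared.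

Compound 4, `COc1ccc(C2=N/C(=C\c3cccnc3)C(=O)O2)cc1OC`, has not yet been measured in this assay. It differs from compound 2 as follows: methoxy in place of hydrogen on an aromatic carbon. The new group enters ortho to the methoxy group already present and para to the large group.

Because compound 2 sits at 100% and compound 3, which also carries a methoxy group with a second substituent on the same ring, gives 92%, the expectation is that the step from compound 2 to compound 4 stays small, with a slight downward tendency at most, a number 15 percentage points lower from compound 2 to compound 4 (beyond the scatter). Compound 4 is therefore estimated at 85%, with a range from 55% to 100%.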

Compound 4, a percentage reported as inhibition, at one concentration (the size of the read-out at that concentration, not a potency): 36%
Compound 4: the middle estimate sits 49 percentage points above what was measured, outside the stated range (below it).
By their numbers in this assay, from the lowest: compound 1; then compound 4; then compounds 3 and 2 (each within the scatter of the next).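

In this assay, methoxy in place of hydrogen on an aromatic carbon, ortho to the methoxy group already present and para to the large group, gives a number 64 percentage points lower from compound 2 to compound 4 (beyond the scatter). Within the data shown here, this is the first single-change step, and it shows that an entering group of 2 heavy atoms at this one position of the six-membered aromatic ring can change the read-out well beyond the scatter, something the earlier compounds, linked by no such step, could not show. The compounds shown offer no measurement that explains the fall.

The compounds shown leave open whether the step belongs to methoxy itself or to any group at this position, since no other group, such as fluorine, a hydroxyl group or an amine, appears there. Among these compounds, they also leave open whether the step depends on the methoxy group already present, since no compound here carries the new methoxy group without it, and a longer chain such as ethoxy at this position is likewise absent from them.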